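The source may report more compounds than this note shows. Statements on the series, on what has been measured and on what is new or still open speak of the compounds shown alone.

Measured compounds:
compound 1 `O=C(Nc1ccc([Se][Se]c2ccc(NC(=O)OCc3ccccc3)cc2)cc1)OCc1ccccc1`, 50900 nM
compound 2 `CCCCOC(=O)Nc1ccc([Se]C#N)cc1`, 43400 nM
compound 3 `CCCCCCOC(=O)Nc1ccc([Se][Se]c2ccc(NC(=O)OCCCCCC)cc2)cc1`, 54300 nM

All three numbers come from a functional assay on HTB-54 cells (Homo sapiens) for cytotoxicity, read by MTT assay, with a stated time of 72 h; a lower number here means a stronger inhibitor of growth, a higher number a weaker inhibitor of growth. In this assay compound 2 shows the lowest of the three numbers, but compound 1 and compound 3 both lie within the usual scatter of it, so the three compounds cannot be told apart on these data.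

Compound 4 `CCCCCCOC(=O)Nc1ccc([Se]C#N)cc1` differs from compound 2 in one place: ethyl in place of hydrogen on a saturated chain carbon, four bonds along the chain from an oxygen next to a carbonyl group. Among the measured compounds shown here, no step between two measured compounds is available to anchor this change. What the data do show is that the butyl carbamate of compound 2 and the hexyl carbamates of compound 3 give numbers within the scatter of each other, though those two compounds differ in more than the chain.

On that basis compound 4 is expected to stay close to compound 2, with the step from compound 2 to compound 4 estimated as a 1.0-fold higher number from compound 2 to compound 4 (0.02 log units; within the scatter), no larger than the scatter. Compound 4 is therefore estimated at 45000 nM, with a range from 20000 nM to 100000 nM.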

Compound 4, concentration for total growth inhibition: 48500 nM
For compound 4 the middle estimate is 1.1-fold (0.03 log units) below the measured one, and the stated range covers the measured number.
By their numbers in this assay, from the lowest: compounds 2, 4, 1 and 3 (each within the scatter of the next).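

In this assay, among the compounds shown here, the step of a 1.1-fold higher number from compound 2 to compound 4 (0.05 log units; within the scatter) gives the first direct reading of ethyl in place of hydrogen on a saturated chain carbon, four bonds along the chain from an oxygen next to a carbonyl group, with the rest of the structure unchanged. Unlike the earlier comparison of compound 2 with compound 3, which differ in more than the chain, this pair isolates the change, and compound 2 and compound 4 cannot be told apart. No available evidence bears on this result.

This single pair leaves open whether the same holds for the same change on other parts of the series. It also leaves open whether a longer chain, a phenyl ring or an amine in place of the ethyl would give a step beyond the scatter.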